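A few compounds are considered here, and "the series" means these few. Any claim that something is new, unique, unknown or untested is made for them only; others in the source may bear on it.

Compound 1 `Cc1cc(NCc2ccc(F)cc2)c2ccccc2n1` is the unsubstituted reference of this series. In a functional assay on MCF-10A cells (Homo sapiens) for antiproliferative activity, with a stated time of 48 h (a lower number here means that less compound is needed, a higher number that more compound is needed for the effect), compound 1 gives 20100 nM. Compound 2 `CCCCCCOc1ccc2nc(C)cc(NCc3ccc(F)cc3)c2c1` carries a hexyloxy in place of hydrogen on an aromatic carbon of the shared core, and in this assay compound 2 gives 9100 nM. That single change produced a 2.2-fold lower number from compound 1 to compound 2 (0.34 log units; beyond the scatter), a modest step. Going by the values given here, compound 2 therefore stands at the lower of the two numbers measured so far, and its only neighbour is compound 1.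

Compound 3 `CCCCCCCCCCOc1ccc2nc(C)cc(NCc3ccc(F)cc3)c2c1` extends the chain of compound 2: butyl in place of hydrogen on a saturated chain carbon, six bonds along the chain from an oxygen on an aromatic ring. Among the compounds with values here, the one measured step that bears on this change is the one from compound 1 to compound 2, in which adding the hexyloxy chain gave a 2.2-fold lower number from compound 1 to compound 2 (0.34 log units; beyond the scatter). A further lengthening of the same chain is a smaller change in kind, so she expects at most a modest further lowering, or a number within the scatter of compound 2, with a 1.5-fold lower number from compound 2 to compound 3 (0.18 log units; within the scatter) as her estimate of the step. For compound 3 she estimates 6000 nM in this assay, with a range from 2500 nM to 15000 nM.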

Compound 3, half-maximal effective concentration: 2000 nM
Compound 3: the middle estimate sits 3.0-fold (0.48 log units) above what was measured; the measured number lies below the stated range.
By their numbers in this assay, from the lowest: compound 3; then compound 2; then compound 1.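

The saturated chain itself proves to count in this assay: butyl in place of hydrogen, six bonds along the chain from an oxygen on an aromatic ring, gives a 4.6-fold lower number from compound 2 to compound 3 (0.66 log units; beyond the scatter), so the lowering seen with the hexyloxy group had not run out at that length. Going by these compounds alone, until now, the only step read at this place was the addition of the whole chain, a 2.2-fold lower number from compound 1 to compound 2 (0.34 log units; beyond the scatter); the new step shows that the outer part of the chain, and not only its presence on the shared core, changes the number. Across the three compounds the number falls as the chain grows and none goes against this, although that is a short series, and nothing at hand explains the effect.

The compounds shown leave open whether a longer chain would lower the number further or whether the trend would stop or turn. They also leave open whether the oxygen that links the chain to the aromatic ring matters, and how a chain ending in an amine or a carboxylic acid would compare with the plain chain of compound 3.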